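The compounds below may be only part of what the source reports. "The series", "measured", "known", "first", "only" and "open" are said of these compounds alone.

Measured compounds:
compound 1 `CCC(C)NC1=NS(=O)(=O)c2cc(Br)ccc2N1`: 5.6 uM
compound 2 `O=S1(=O)NC(NC2CCC2)=Nc2ccc(Br)cc21`: 21.7 uM
compound 3 `CCC(C)NC1=NS(=O)(=O)c2cc(I)ccc2N1`: 1.3 uM

In a functional assay (aorta) with Rattus norvegicus as the target (a lower number here means that less compound is needed, a higher number that more compound is needed for the effect), compound 1 gives 5.6 uM, while compound 3 gives 1.3 uM. These two differ in a single place, (iodo in place of bromo on an aromatic carbon), and that change produced a 4.3-fold lower number from compound 1 to compound 3 (0.63 log units; beyond the scatter). Compound 2 rests on another core, and in this assay compound 2 gives 21.7 uM, the highest of the three numbers. The difference between the core of compound 2 and the core of compound 1 is not broken down here.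

Compound 4 `O=S1(=O)NC(NC2CCC2)=Nc2ccc(I)cc21` has not yet been measured. It differs from compound 2 by iodo in place of bromo on an aromatic carbon, the same change, at the same kind of place, that separates compound 1 from compound 3. If that change carries over to the core of compound 2, it is expected that a 4.3-fold lower number from compound 2 to compound 4 (0.64 log units; beyond the scatter), the size resting on a 4.3-fold lower number from compound 1 to compound 3 (0.63 log units; beyond the scatter). For the measured compounds named here, with only one measured pair showing this change, the carry-over remains a supposition rather than a pattern. For compound 4 the estimated value in this assay is 5 uM, expected to fall between 2 uM and 12 uM.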

Compound 4, concentration for half-maximal effect: 22.2 uM
Compound 4: middle estimate off by 4.4-fold (0.65 log units), on the low side, outside the stated range (above it).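

In this assay, iodo in place of bromo on an aromatic carbon gave a 1.0-fold higher number from compound 2 to compound 4 (0.01 log units; within the scatter), so on the core of compound 2 this change left no mark that can be told from the scatter. Set beside the earlier step, the result shows that the change does not behave alike on the two cores: the same change on two cores in this assay, a 4.3-fold lower number (0.63 log units; beyond the scatter) from compound 1 to compound 3 and a 1.0-fold higher number (0.01 log units; within the scatter) from compound 2 to compound 4, 4.4-fold (0.64 log units) apart, beyond the scatter of two such steps. The gain seen on the core of compound 1 therefore cannot be taken as a property of the change alone in this series, yet these two pairs do not show which feature of the cores separates the steps, nor how the change would behave on any third core.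

The compounds shown leave open how a chloro group or a nitrile in the same place would behave on either core. Also open, from the compounds shown here alone, is whether a cyclopentyl group or a straight butyl chain on the amino nitrogen would make the step from bromo to iodo follow the first pair or the second.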